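The source may hold more compounds than are shown below. What is called first, only, known or untested is meant among the compounds shown, and "the series" means these compounds.

Compound 3 `O=c1[nH]/c(=C\c2cccs2)c(=O)[nH]/c1=C\c1cccc(Oc2ccc(F)cc2)c1` stands at > 1000 nM in a functional assay on NCI-H460 cells (Homo sapiens) for cytotoxicity, read by MTT assay, with a stated time of 72 h (on this read-out lower numbers stand for stronger inhibition and higher numbers for weaker inhibition), and this value is a limit of the assay, not a number. Compound 1 `CC(C)c1[nH]cnc1/C=c1\[nH]c(=O)/c(=C/c2cccc(Oc3ccc(F)cc3)c2)[nH]c1=O` gives 8.8 nM in this assay and compound 2 `O=c1[nH]/c(=C\c2nc[nH]c2C2CC2)c(=O)[nH]/c1=C\c1cccc(Oc2ccc(F)cc2)c1` gives 15.2 nM in the same test, two values within the scatter (a 1.7-fold higher number from compound 1 to compound 2 (0.24 log units; within the scatter)). Two large steps lead to compound 3 (an at least 110-fold higher number from compound 1 to compound 3 (2.05 log units; beyond the scatter); an at least 65-fold higher number from compound 2 to compound 3 (1.81 log units; beyond the scatter)), each putting thiophen-2-yl in place of an imidazolyl group. Compound 4 `O=c1[nH]/c(=C\c2ccc(CO)o2)c(=O)[nH]/c1=C\c1cccc(Oc2ccc(F)cc2)c1` differs from compound 3 by 5-(hydroxymethyl)furan-2-yl in place of thiophen-2-yl on a double-bonded chain carbon bound to an aromatic carbon and so carries 5-(hydroxymethyl)furan-2-yl in place of thiophen-2-yl. Going by the values given here, no measured step covers this exchange directly. The expectation rests on the large step (an at least 110-fold higher number from compound 1 to compound 3 (2.05 log units; beyond the scatter)) since compound 4, like compound 3, has no imidazolyl group. No change beyond the scatter is expected, and the estimated step is small (a step that the limit leaves unreadable from compound 3 to compound 4). For compound 4 the estimated value is 1500 nM with an expected range of 300 nM to 6000 nM in this assay.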

Compound 4, half-maximal inhibitory concentration: 41.5 nM
Compound 4: the middle estimate sits 36-fold (1.56 log units) above what was measured; the measured number lies below the stated range.
By their numbers in this assay, from the lowest: compounds 1 and 2 (each within the scatter of the next); then compound 4. At a limit, above all of these: compound 3.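

In this assay, an imidazolyl group is not required for a low number at this place on a double-bonded chain carbon bound to an aromatic carbon: 5-(hydroxymethyl)furan-2-yl in place of thiophen-2-yl gives a large step (an at least 24-fold lower number from compound 3 to compound 4 (1.38 log units; beyond the scatter)). Compound 3 stands at a limit, not a number: the limit of > 1000 nM in this assay, at which 1 of the 4 values shown sits. Compound 4 still stays modestly behind both imidazolyl compounds (a 2.7-fold higher number from compound 2 to compound 4 (0.44 log units; beyond the scatter); a 4.7-fold higher number from compound 1 to compound 4 (0.67 log units; beyond the scatter)).

The compounds shown do not separate the furan ring from the hydroxymethyl group as the source of this step. They also leave open how an aminomethyl group or a carboxylic acid in place of the hydroxymethyl would read.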